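The source may report more compounds than this note shows. Statements on the series, on what has been measured and on what is new or still open speak of the compounds shown alone.

Among the measured compounds shown here, compound 1 `ClCc1ccccc1Cn1cnc2c(Cl)nc(Cl)nc21` is one of two compounds measured in a functional assay on ACHN cells (Homo sapiens) for cytotoxicity, read by sulforhodamine B assay, with a stated time of 48 h; a higher number here means a weaker inhibitor of growth, a lower number a stronger inhibitor of growth. In this assay compound 1 gives 470 nM, and compound 2 `ClCc1cccc(Cn2cnc3c(Cl)ncnc32)c1` gives 2080 nM; of the two numbers, that of compound 1 is the lower, and the gap between them lies beyond the usual scatter of repeated measurements. Compound 1 thus stands as the stronger inhibitor of growth of the two.

Compound 3 `Nc1nc(Cl)c2ncn(Cc3ccccc3CCl)c2n1` has not yet been measured. It differs from compound 1 in one place: amino in place of chloro on an aromatic carbon. In plain words, an amino group replaces a chloro group on an aromatic carbon of the shared core, at the position between two ring nitrogen atoms.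

For the measured compounds named here, no pair of measured compounds that differ in this one place is available, so the size of the step can only be expected, not read from data. The step from compound 1 to compound 3 is expected to be a 1.9-fold higher number from compound 1 to compound 3 (0.28 log units; within the scatter), a modest rise in the number, perhaps not far beyond the scatter. For compound 3 the estimate in this assay is 900 nM, with a range from 250 nM to 3500 nM.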

Compound 3, concentration for 50% growth inhibition: 5750 nM
For compound 3 the middle estimate is 6.4-fold (0.81 log units) below the measured one; the whole stated range lies below it.
By their numbers in this assay, from the lowest: compound 1; then compound 2; then compound 3.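

In this assay, among the compounds shown here, the aromatic carbon between two ring nitrogen atoms proves sensitive to what it carries: amino in place of chloro gives a 12-fold higher number from compound 1 to compound 3 (1.09 log units; beyond the scatter) and provides the first direct reading of a change at this position. The exchange is small in the terms that can be counted, one heavy atom for one heavy atom with no net charge on either group, yet it leaves compound 3 a clearly weaker inhibitor of growth than compound 1. Nothing measured here accounts for the size of this step, so it stands as an observation without an explanation.

The compounds shown do not tell whether this rise in the number is particular to amino or would follow any replacement of chloro at this position, since a methyl group, a methoxy group and a dimethylamino group do not appear among them. They also leave open whether the same exchange would carry the same weight at the other chloro group on the shared core, or with the chloromethyl group placed differently on the benzene ring.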